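The source may report more compounds than this note shows. Statements on the series, on what has been measured and on what is new or still open speak of the compounds shown alone.

Three compounds built on one shared core were tested in an ADME assay on Huh-7 cells (Homo sapiens) for cytotoxicity, read by fluorescence, with a stated time of 3 days; a lower number here means that less compound is tolerated, a higher number that more compound is tolerated. Compound 1 `CC(C)N(c1cc(C#CC(C)(C)C)sc1C(=O)O)C(=O)[C@H]1CC[C@H](C)CC1` carries isopropyl on an amide-type nitrogen. In this assay compound 1 reaches only > 44000 nM, which is a limit of the assay and not a number. Compound 2 `CN(c1ccncc1)N(c1cc(C#CC(C)(C)C)sc1C(=O)O)C(=O)[C@H]1CC[C@H](C)CC1` has methyl(pyridin-4-yl)amino in place of isopropyl on that nitrogen, and in this assay compound 2 gives 36000 nM. Compound 3 `CN([C@H]1CC[C@H](O)CC1)N(c1cc(C#CC(C)(C)C)sc1C(=O)O)C(=O)[C@H]1CC[C@H](C)CC1` carries (4-hydroxycyclohexyl)(methyl)amino on the same nitrogen. In this assay compound 3 also stops at > 44000 nM, a limit, so only a limit is known for it. The step of an at least 1.2-fold lower number from compound 1 to compound 2 (0.08 log units; that floor lies within the scatter) and the step of an at least 1.2-fold higher number from compound 2 to compound 3 (0.08 log units; that floor lies within the scatter) both sit at a floor within the scatter, and the step that the two limits leave unreadable from compound 1 to compound 3 cannot be read because the limit of > 44000 nM in this assay, at which 2 of the 3 values shown sit, holds both of its ends.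

Compound 4 `CN1CCC(N(C)N(c2cc(C#CC(C)(C)C)sc2C(=O)O)C(=O)[C@H]2CC[C@H](C)CC2)CC1` differs from compound 3 by 1-methylpiperidin-4-yl in place of 4-hydroxycyclohexyl on an amine nitrogen. The nearest measured step, an at least 1.2-fold higher number from compound 2 to compound 3 (0.08 log units; that floor lies within the scatter), also exchanged one ring for another on that amine nitrogen and moved nothing beyond the scatter, so no step beyond the scatter is expected here either, and the expected step is a number no higher from compound 3 to compound 4 (the limit leaves the size open). Compound 4 is therefore estimated at 44000 nM, between 20000 nM and 90000 nM, with a good chance that this assay again reports only a limit.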

Compound 4, half-maximal cytotoxic concentration: > 44000 nM
Compound 4: a limit, no number; the forecaster's own chance of this, stated with the estimate: 65%; the middle value lies on the limit itself.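

In this assay compound 4 gives > 44000 nM, which is a limit and not a number, so a six-membered ring with a hetero atom, 1-methylpiperidin-4-yl, on the amine nitrogen gives a result of the same kind as the carbon-only ring 4-hydroxycyclohexyl. Among the compounds shown here, the only readable comparison is with pyridin-4-yl on that nitrogen, an at least 1.2-fold higher number from compound 2 to compound 4 (0.08 log units; that floor lies within the scatter), so this third ring, like the earlier exchange of rings there, shows no step beyond the scatter. The steps to compound 4 from compound 1 and from compound 3 cannot be read because both ends of each are limits: the limit of > 44000 nM in this assay, at which 3 of the 4 values shown sit.

As far as these compounds go, the order among compound 1, compound 3 and compound 4 therefore stays unknown, and the change from a hydroxyl group to a ring nitrogen has no readable size. Also open, from the compounds shown here alone, is whether a carboxylic acid or a longer chain in place of 1-methylpiperidin-4-yl on the amine nitrogen would give a step beyond the scatter.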